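Vinyl for ethyl on the amide carbonyl

The source may report more compounds than this note shows. Statements on the series, on what has been measured and on what is new or still open speak of the compounds shown alone.

Measured compounds:
Compound 1 `CCC(=O)N(Cc1ccc(OC)c(O)c1)c1cc(OC)c(OC)c(OC)c1` — 61 nM in a functional assay on HCT-116 cells (Homo sapiens) for inhibition, read by MTT assay, with a stated time of 48 h; a higher number here means a weaker inhibitor, a lower number a stronger inhibitor
Compound 2 `COc1cc(NCc2ccccc2)cc(OC)c1OC` — in this assay compound 2 reaches only the assay limit, > 80000 nM.

Among the measured compounds shown here, compound 1 is the only compound with a numerical result here; the one further value shown is a limit, not a number (the limit of > 80000 nM in this assay, at which 1 of the 2 values shown sits). For the measured compounds named here, compounds 1 and 2 differ in more than one place, so no single step between them is counted; of that pair one can say only that compound 1 gives a number and compound 2 gives a limit.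

The next compound, compound 3 `C=CC(=O)N(Cc1ccc(OC)c(O)c1)c1cc(OC)c(OC)c(OC)c1`, keeps the whole of compound 1 except for one exchange: vinyl in place of ethyl on a carbonyl carbon. The acyl chain keeps its size and loses no donor or acceptor; the only gain is the double bond outside aromatic rings. With no measured step of this kind in the set, the expected shift is small, a 1.5-fold lower number from compound 1 to compound 3 (0.18 log units; within the scatter), most likely within the usual scatter and, if anything, toward the stronger side.

Compound 3 is estimated at 40 nM, with a range of 12 nM to 150 nM.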

Compound 3, half-maximal inhibitory concentration: 98 nM
Compound 3: middle estimate off by 2.5-fold (0.39 log units), on the low side; the range from low to high includes it.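

In this assay, among the compounds shown here, the exchange of ethyl for vinyl on a carbonyl carbon gives the first single-place step, and it stays within the scatter (a 1.6-fold higher number from compound 1 to compound 3 (0.21 log units; within the scatter)). At this place, on a carbonyl carbon whose other neighbour is the amide-type nitrogen, propanoyl and vinylcarbonyl therefore cannot be told apart in this assay, so the double bond outside aromatic rings can be carried here without a measurable cost or gain. Nothing among the measurements shown gives a reason for this result, and no cause can be assigned to either acyl group.

The compounds shown leave open how much more the acyl group can take, since a longer chain such as butanoyl, a cyclopropyl group, a chloromethyl group or a chain ending in an amine does not appear among them. This one step also says nothing about the other parts of the core of compound 1, where any exchange of the hydroxyl or methoxy groups would need its own single-place comparison in this assay.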